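Swapping the aryl on the piperazine of compound 1

This account rests on a few compounds, and the source may have more. Where it says the series, first, only, none or still open, it means among the compounds named here.

Of the compounds shown here, three sharing one core have been measured in an assay on HEK293 cells for inhibition of Voltage-dependent T-type calcium channel subunit alpha-1G (Homo sapiens), read by fluorescence, tested at 10 uM; on this read-out higher numbers stand for more inhibition at the one concentration tested (going by the name of the read-out) and lower numbers for less inhibition. Compound 1, `CCCc1nc(-c2ccccc2)c(CNCCCN2CCN(c3cccc(C(F)(F)F)c3)CC2)o1`, gives 51.6%. Compound 2, `CCCc1nc(-c2ccccc2)c(CNCCN2CCN(c3ccc(C)cc3)CC2)o1`, gives 48.1%, and compound 3, `CCCc1nc(-c2ccccc2)c(CNCCN2CCN(c3ccc(OC)cc3)CC2)o1`, gives 51.5%. All three numbers sit within the scatter of one another, so compound 1 cannot be set apart from compound 2 or compound 3 on these values. Within the data shown here, the one single-point step among them, a number 3.4 percentage points higher from compound 2 to compound 3 (within the scatter), shows that exchanging these two groups on the aryl ring left the read-out essentially unchanged.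

The next compound, compound 4, `CCCc1nc(-c2ccccc2)c(CNCCCN2CCN(c3ccccc3OC)CC2)o1`, differs from compound 1 by 2-methoxyphenyl in place of 3-(trifluoromethyl)phenyl on an amine nitrogen in a ring. Among the measured compounds shown here, no measured pair covers this exact exchange, so the expectation rests on the weak response already seen between compound 2 and compound 3 and on the near-identical values of all three compounds. The change from compound 1 to compound 4 is therefore expected to stay within the scatter, a number 3.6 percentage points lower from compound 1 to compound 4 (within the scatter), and compound 4 is estimated at 48% with a range from 30% to 65%.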

Compound 4, a percentage reported as inhibition, at one concentration (the size of the read-out at that concentration, not a potency): 41%
Compound 4: the middle estimate sits 7 percentage points above what was measured; the measured number falls inside the stated range.
By their numbers in this assay, from the lowest: compounds 4, 2, 3 and 1 (each within the scatter of the next, the first and the last beyond it).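

In this assay, the exchange of 3-(trifluoromethyl)phenyl for 2-methoxyphenyl on an amine nitrogen in a ring gives a number 10.6 percentage points lower from compound 1 to compound 4 (beyond the scatter) and so shows that the read-out can respond to the aryl group at this position. Among these compounds, the only earlier step, a number 3.4 percentage points higher from compound 2 to compound 3 (within the scatter), could not be told from the scatter, whereas this modest step can, though it rests on a single exchange. Nothing available here bears on why the number fell, so the change cannot be explained.

This exchange alters both the group on the aryl ring and where it sits, so the two remain inseparable. On these data alone, a 3-methoxyphenyl or 2-(trifluoromethyl)phenyl on the same nitrogen would separate them, and the effect of an unsubstituted phenyl there also remains open.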